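From a bromothiophene to an indole on the carbonyl carbon

This account rests on a few compounds, and the source may have more. Where it says the series, first, only, none or still open, it means among the compounds named here.

Of the compounds shown here, two sharing one core have been measured. Compound 1 `COc1ccc(-c2cc3ccccc3nc2/C=C/C(=O)c2ccc(O)cc2)cc1` carries a 4-hydroxyphenyl group on the carbonyl carbon; in a functional assay on H184B5F5/M10 cells (Homo sapiens) for antiproliferative activity, read by XTT assay, with a stated time of 72 h (on this read-out higher numbers stand for weaker inhibition and lower numbers for stronger inhibition), compound 1 gives 5690 nM. Compound 2 `COc1ccc(-c2cc3ccccc3nc2/C=C/C(=O)c2ccc(Br)s2)cc1` carries a 5-bromothiophen-2-yl group on that carbonyl carbon, and in this assay compound 2 gives 9380 nM. For the measured compounds named here, the one step between them, a 1.6-fold higher number from compound 1 to compound 2 (0.22 log units; within the scatter), shows that this exchange left the read-out within the scatter. Of the two numbers shown, that of compound 2 is the higher, but its gap to compound 1 is within the scatter, so nothing separates the two.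

The next compound, compound 3 `COc1ccc(-c2cc3ccccc3nc2/C=C/C(=O)c2c[nH]c3ccccc23)cc1`, differs from compound 2 in one place: 1H-indol-3-yl in place of 5-bromothiophen-2-yl on a carbonyl carbon. Going by the values given here, only one measured step bears on a change of this kind, the exchange on the carbonyl carbon from compound 1 to compound 2, and that step stayed within the scatter. The step from compound 2 to compound 3 in this assay is therefore expected to be a 1.3-fold lower number from compound 2 to compound 3 (0.13 log units; within the scatter), not beyond the scatter in either direction. Compound 3 is accordingly estimated at 7000 nM in this assay, with a range from 2500 nM to 20000 nM.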

Compound 3, half-maximal inhibitory concentration: > 10000 nM
Compound 3 ended at the assay's limit; the forecaster's own chance of this, stated with the estimate: 10%; middle value at least 1.4-fold (0.15 log units) away from the limit.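

With 1H-indol-3-yl on the carbonyl carbon, the read-out of compound 3 in this assay is a limit of the assay and not a number: the limit of > 10000 nM in this assay, at which 1 of the 3 values shown sits. Read as floors, the record gives an at least 1.0-fold higher number from compound 2 to compound 3 (0.02 log units; that floor lies within the scatter), and an at least 1.7-fold higher number from compound 1 to compound 3 (0.24 log units; that floor lies within the scatter); both floors lie within the scatter, so neither step shows that the indole differs from the earlier groups. What compound 3 adds is that a group with a five-membered and a six-membered aromatic ring on this carbonyl carbon brought no lower number than the single-ring groups of compound 1 and compound 2, so the position has now taken three different aromatic groups without any step beyond the scatter.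

The compounds shown leave open how far the value of compound 3 lies past the limit, and with it whether the change from 5-bromothiophen-2-yl to 1H-indol-3-yl has any real size. They also leave open whether a non-aromatic group on the carbonyl carbon, such as an aliphatic amine, a carboxylic acid or a longer chain, would move the number beyond the scatter in either direction.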